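From Bromo to Methoxy on a Shared Core

The compounds below may be only part of what the source reports. "The series", "measured", "known", "first", "only" and "open" are said of these compounds alone.

For the measured compounds named here, compound 3 `CC1(C)CNC(=O)c2cc3n(c2C1)CCc1cc(Br)ccc1-3` is the one compound here with an actual number in a functional assay on U-251 cells (Homo sapiens) for cytotoxicity, read by sulforhodamine B assay, with a stated time of 48 h (on this read-out higher numbers stand for weaker inhibition and lower numbers for stronger inhibition), giving 18100 nM. Compound 1 `CC1(C)CNC(=O)c2cc3n(c2C1)CCc1ccccc1-3` reaches only a limit of the assay, > 100000 nM. Compound 2 `CC1(C)CNC(=O)c2cc3n(c2C1)CCc1cc(Cl)ccc1-3` likewise reaches only a limit, > 100000 nM. Bringing in bromo made a sizeable difference: an at least 5.5-fold lower number from compound 1 to compound 3 (0.74 log units; beyond the scatter), and an at least 5.5-fold lower number from compound 2 to compound 3 (0.74 log units; beyond the scatter), whereas the step that the two limits leave unreadable from compound 1 to compound 2. Compound 4 `COc1ccc2c(c1)CCn1c-2cc2c1CC(C)(C)CNC2=O` carries methoxy in place of bromo on an aromatic carbon. Going by the values given here, no measured step involves methoxy, so the change can be judged only by what removing bromo may undo. Bromo gave the single measurable number, so its loss is expected to push the number back upward, a 3.3-fold higher number from compound 3 to compound 4 (0.52 log units; beyond the scatter). Compound 4 is therefore estimated at 60000 nM, within 15000 nM to 200000 nM.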

Compound 4, half-maximal inhibitory concentration: > 100000 nM
Compound 4 ended at the assay's limit (the forecaster's own chance of this, stated with the estimate: 50%); middle value at least 1.6-fold (0.22 log units) from the limit.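

In this assay, putting methoxy in place of bromo on this aromatic carbon brings an at least 5.5-fold higher number from compound 3 to compound 4 (0.74 log units; beyond the scatter). Methoxy therefore does not keep what bromo brought, and of the four groups shown on this carbon, only bromo gives a number short of the limit. The steps from compound 1 and compound 2 to compound 4 join limit to limit and cannot be read, leaving a single number against this ceiling: the limit of > 100000 nM in this assay, at which 3 of the 4 values shown sit.

Going by these compounds, whether iodo or an amine on this carbon would also give a measurable number remains open. So does whether any such group could bring the number lower than bromo does.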